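The source may hold more compounds than are shown below. What is called first, only, known or untested is meant among the compounds shown, and "the series" means these compounds.

Measured in a functional assay for inhibition, with Sus scrofa as the target; a higher number here means a weaker inhibitor, a lower number a stronger inhibitor:
- compound 1 `CC1(C)C=C(n2ccccc2=O)c2cc(C#N)ccc2O1`: 50 nM
- compound 2 `Cn1nc(O[C@@H]2c3cc(C#N)ccc3OC(C)(C)[C@H]2O)ccc1=O`: 50 nM
- compound 3 `CC1(C)Oc2ccc(C#N)cc2[C@@H](n2ccccc2=O)[C@]1(C)O`: > 100000 nM

Compound 1, at 50 nM, stands level with compound 2, at 50 nM, within the scatter of the measurement. Compound 3 gives > 100000 nM, which is a limit of the assay and not a number.

Compound 4 `CC1=C(n2ccccc2=O)c2cc(C#N)ccc2OC1(C)C` keeps the core of compound 1 and makes one change, methyl in place of hydrogen on a double-bonded ring carbon.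

Among the measured compounds shown here, no measured pair isolates this change, so the expectation rests on thin evidence. Compound 3 also bears a methyl group on the ring carbon next to the ring atom that bears two methyl groups, and it sits at > 100000 nM, a limit. It differs from compound 1 in more than that methyl, so it serves only as a warning.

A moderate weakening beyond the scatter is expected, with the step estimated as a 6.0-fold higher number from compound 1 to compound 4 (0.78 log units; beyond the scatter). For compound 4 the estimated value is 300 nM, with an expected range of 40 nM to 3000 nM.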

Compound 4, half-maximal inhibitory concentration: 5000 nM
Beside the measured number, compound 4's estimate is 17-fold (1.22 log units) below it; the whole stated range lies below it.
By their numbers in this assay, from the lowest: compounds 1 and 2 (each within the scatter of the next); then compound 4. At a limit, above all of these: compound 3.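

In this assay, replacing hydrogen with methyl on a double-bonded ring carbon gives a 100-fold higher number from compound 1 to compound 4 (2.00 log units; beyond the scatter), a large step beyond the scatter. This is the first pair shown that isolates this position, and it shows that this single added carbon is enough to lose most of the activity of compound 1. Compound 4 gives a measured number rather than a limit, so the size of this step can be read in full: the limit of > 100000 nM in this assay, at which 1 of the 4 values shown sits.

From the compounds shown here alone, only hydrogen and methyl can be compared at this carbon, so it remains open whether a fluorine atom or an ethyl group would behave like hydrogen or like methyl. The compounds shown also leave open why the methyl group costs so much activity at this position.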